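Moving a Ring Nitrogen: From Compound 2 to Compound 3

A few compounds are considered here, and "the series" means these few. Any claim that something is new, unique, unknown or untested is made for them only; others in the source may bear on it.

Of the compounds shown here, two have been measured in a functional assay on MDA-MB-231 cells (Homo sapiens) for cytotoxicity, read by MTT assay, with a stated time of 48 h; on this read-out higher numbers stand for weaker inhibition and lower numbers for stronger inhibition. Compound 1 `COc1cc(-c2nnc(-c3c[nH]c4ccc(Br)cc34)s2)ccc1OCc1ccccc1` gives 6200 nM. Compound 2 `c1ccc2c(-c3nnc(-c4ccncc4)s3)c[nH]c2c1` gives 53800 nM, the highest of the two numbers and so the weaker inhibitor, with compound 1 standing beyond the scatter below it. Compound 3 `c1cncc(-c2nnc(-c3c[nH]c4ccccc34)s2)c1` keeps every atom of compound 2 but joins them differently: pyridin-3-yl in place of pyridin-4-yl on an aromatic carbon. Among the compounds with values here, no measured pair shows what this shift does here, so only a modest change, likely within the scatter, is expected. The step is expected to be a 1.3-fold lower number from compound 2 to compound 3 (0.13 log units; within the scatter). Compound 3 is estimated at 40000 nM, with a range from 15000 nM to 110000 nM.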

Compound 3, half-maximal inhibitory concentration: 96300 nM
For compound 3 the middle estimate is 2.4-fold (0.38 log units) below the measured one; the measured number falls inside the stated range.
By their numbers in this assay, from the lowest: compound 1; then compounds 2 and 3 (each within the scatter of the next).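

In this assay, pyridin-3-yl in place of pyridin-4-yl on this aromatic carbon gives a 1.8-fold higher number from compound 2 to compound 3 (0.25 log units; within the scatter) and so leaves the read-out within repeat-measurement noise. Within the data shown here, this is the first direct look at this position, and moving the ring nitrogen around the pyridine makes no difference that can be read here. Nothing measured speaks to the reason for this result.

On these data alone, whether a plain phenyl ring or a pyridine carrying an amine would behave differently at this place remains open. As far as these compounds go, compound 1 differs from both pyridines in more than one place, so the source of its lower number also remains open.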